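Notes on a 2-fluorophenyl swap in the series

A few compounds are considered here, and "the series" means these few. Any claim that something is new, unique, unknown or untested is made for them only; others in the source may bear on it.

In a functional assay on MCF-10A cells (Homo sapiens) for antiproliferative activity, with a stated time of 48 h (on this read-out lower numbers stand for an effect already at smaller amounts and higher numbers for an effect only at larger amounts of compound), compound 1 (`COc1ccc2nc(C)cc(NCc3cccnc3)c2c1`) gives 49300 nM and compound 2 (`COc1ccc2nc(C)cc(SCc3ccccc3)c2c1`) gives 37100 nM, two numbers within the scatter of each other at the high end of the set. Compound 3 (`COc1ccc2nc(C)cc(NCc3ccc(C(C)(C)C)cc3)c2c1`) gives 7000 nM, beyond the scatter below compound 1. Compound 4 (`COc1ccc2nc(C)cc(NCc3ccccc3F)c2c1`) carries 2-fluorophenyl in place of pyridin-3-yl on a saturated chain carbon bound to a nitrogen on an aromatic ring. For the measured compounds named here, no measured pair isolates a single change, so the evidence is thin. Compound 3 at 7000 nM marks the lowest number seen so far. A modest move toward lower numbers in this assay is expected, a 2.0-fold lower number from compound 1 to compound 4 (0.29 log units; within the scatter). Compound 4 is estimated at 25000 nM, with an expected range of 9000 nM to 60000 nM.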

Compound 4, half-maximal effective concentration: 17000 nM
For compound 4 the middle estimate is 1.5-fold (0.17 log units) above the measured one; the range from low to high includes it.
By their numbers in this assay, from the lowest: compound 3; then compound 4; then compounds 2 and 1 (each within the scatter of the next).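

For the compounds shown here, this is the first comparison that isolates a single place. In this assay there is a 2.9-fold lower number from compound 1 to compound 4 (0.46 log units; beyond the scatter) with 2-fluorophenyl in place of pyridin-3-yl on a saturated chain carbon bound to a nitrogen on an aromatic ring, so the number responds to the group held here while the rest of the structure stays fixed. No measured evidence bears on why this step occurs.

Still open, as far as these compounds go, is whether the fluorine or the loss of the ring nitrogen accounts for the step. Also open, from the compounds shown here alone, is how a cyclohexyl group, an amine or a carboxylic acid would read at this place.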